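Hydroxamic acid placement in a hydantoin series of HDAC6 inhibitors

The source may hold more compounds than are shown below. What is called first, only, known or untested is meant among the compounds shown, and "the series" means these compounds.

Measured compounds:
compound 1 `Cc1ccc(CN2C(=O)N(c3ccc(Cl)cc3)C(=O)C2CCC(=O)Nc2cccc(C(=O)NO)c2)cc1`: > 40 nM
compound 2 `Cc1ccc(CN2C(=O)N(c3ccc(Cl)cc3)C(=O)C2CCC(=O)NCc2ccc(C(=O)NO)cc2)cc1`: 18.9 nM
compound 3 `O=C(CCC1C(=O)N(c2ccc(Cl)cc2)C(=O)N1Cc1ccccc1)Nc1cccc(C(=O)NO)c1`: > 40 nM

In an assay on isolated protein for inhibition of protein deacetylase HDAC6 (Homo sapiens), read by fluorescence, with stated times of 5 min and 60 min (a higher number here means a weaker inhibitor, a lower number a stronger inhibitor), compound 1 gives only a limit, > 40 nM. Compound 3 likewise gives only a limit in this assay, > 40 nM. Compound 2, by contrast, gives 18.9 nM in this assay. Compound 1 and compound 2 differ in one place, (4-(hydroxycarbamoyl)benzyl in place of 3-(hydroxycarbamoyl)phenyl on an amide-type nitrogen), and this change gave an at least 2.1-fold lower number from compound 1 to compound 2 (0.32 log units; beyond the scatter). Compound 1 and compound 3 differ in their cores, (hydrogen in place of methyl on an aromatic carbon), and the step between them is a step that the two limits leave unreadable from compound 1 to compound 3 because of the limit of > 40 nM in this assay, at which 2 of the 3 values shown sit.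

Compound 4 `O=C(CCC1C(=O)N(c2ccc(Cl)cc2)C(=O)N1Cc1ccccc1)NCc1ccc(C(=O)NO)cc1` is not yet measured. It stands to compound 3 as compound 2 stands to compound 1: the change is the same, (4-(hydroxycarbamoyl)benzyl in place of 3-(hydroxycarbamoyl)phenyl on an amide-type nitrogen), made on the same kind of amide-type nitrogen. Since the step from compound 1 to compound 2 was an at least 2.1-fold lower number from compound 1 to compound 2 (0.32 log units; beyond the scatter), and since compound 3 sits at the same limit as compound 1, the corresponding step is expected to be an at least 2.0-fold lower number from compound 3 to compound 4 (0.30 log units; that floor lies within the scatter). Compound 4 is therefore estimated to give about 20 nM in this assay, most likely between 8 nM and 60 nM.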

Compound 4, half-maximal inhibitory concentration: 12.7 nM
The estimate for compound 4 lay 1.6-fold (0.20 log units) above the measured number, and the stated range covers the measured number.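

In this assay, the change from 3-(hydroxycarbamoyl)phenyl to 4-(hydroxycarbamoyl)benzyl on the amide-type nitrogen carries over to the core without the methyl, giving an at least 3.1-fold lower number from compound 3 to compound 4 (0.49 log units; beyond the scatter). The two cases point the same way, but this rests on one pair per core, and the cores differ only by that methyl, so it shows nothing about more distant cores, and the sizes of the two steps cannot be compared: the same change on two cores in this assay, an at least 2.1-fold lower number (0.32 log units; beyond the scatter) from compound 1 to compound 2 and an at least 3.1-fold lower number (0.49 log units; beyond the scatter) from compound 3 to compound 4; the limit leaves it open whether they differ. With the 4-(hydroxycarbamoyl)benzyl group in place, hydrogen in place of methyl gives a 1.5-fold lower number from compound 2 to compound 4 (0.17 log units; within the scatter), while the same replacement cannot be read with the 3-(hydroxycarbamoyl)phenyl group, where compound 1 and compound 3 both sit at a limit: the limit of > 40 nM in this assay, at which 2 of the 4 values shown sit.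

The position of the hydroxycarbamoyl group and the extra carbon change together here, and the compounds shown leave open which of the two matters. A 4-(hydroxycarbamoyl)phenyl or a 3-(hydroxycarbamoyl)benzyl group on the same nitrogen would separate them.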